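Benzofuran for furan on two shared cores

This account rests on a few compounds, and the source may have more. Where it says the series, first, only, none or still open, it means among the compounds named here.

Compound 2 `Cc1ncnc2c1c(-c1ccoc1)cn2[C@@H]1O[C@H](CO)[C@@H](O)[C@H]1O` and compound 1 `Cc1ncnc2c1c(-c1cc3ccccc3o1)cn2[C@@H]1O[C@H](CO)[C@@H](O)[C@H]1O` share one core; compound 3 `Cc1nc(N)c2c(-c3ccoc3)cn([C@@H]3O[C@H](CO)[C@@H](O)[C@H]3O)c2n1` and compound 4 `Cc1nc(N)c2c(-c3cc4ccccc4o3)cn([C@@H]3O[C@H](CO)[C@@H](O)[C@H]3O)c2n1` share another, and the difference between the two cores is not broken down here. In an ADME assay on BJ cells (Homo sapiens), read by MTT assay, with a stated time of 72 h (a lower number here means a stronger inhibitor, a higher number a weaker inhibitor), compound 2 gives 89200 nM. Compound 1 gives 93900 nM in this assay. The change 1-benzofuran-2-yl in place of furan-3-yl on an aromatic carbon made the step of a 1.1-fold higher number from compound 2 to compound 1 (0.02 log units; within the scatter). For compound 3, this assay returns only a limit, > 100000 nM, which is the limit of > 100000 nM in this assay, at which 1 of the 3 values shown sits. The change 1-benzofuran-2-yl in place of furan-3-yl on an aromatic carbon is the same change, made on the other core. Given that compound 3 stands at the limit and the earlier step of a 1.1-fold higher number from compound 2 to compound 1 (0.02 log units; within the scatter) stayed within the scatter, compound 4 is expected to remain near that limit, a step that the limit leaves unreadable from compound 3 to compound 4. Compound 4 is therefore estimated at 110000 nM, within 55000 nM to 250000 nM.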

Compound 4, half-maximal inhibitory concentration: > 100000 nM
Compound 4 ended at the assay's limit (the forecaster's own chance of this, stated with the estimate: 70%); the middle value lies beyond the limit too.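

No step can be read from compound 3 to compound 4, as both stand only as limits in this assay. On these data alone, what 1-benzofuran-2-yl in place of furan-3-yl does on the core of compound 3 remains open.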